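Fluorophenyl positional isomer in the benzyloxy series

The source may hold more compounds than are shown below. What is called first, only, known or untested is meant among the compounds shown, and "the series" means these compounds.

Measured compounds:
- compound 1, `C=CCOc1ccc2c(=O)c(-c3cc(OC)c(OC)cc3OC)coc2c1`: 5900 nM
- compound 2, `COc1cc(OC)c(-c2coc3cc(OCc4ccccc4F)ccc3c2=O)cc1OC`: 2890 nM
- compound 3, `COc1cc(OC)c(-c2coc3cc(OCc4ccc(C#N)cc4)ccc3c2=O)cc1OC`: 6180 nM

All three share one core and differ only in the group on a saturated chain carbon bound to an oxygen on an aromatic ring. In a functional assay on U-251 cells (Homo sapiens) for antiproliferative activity, read by MTT assay, with a stated time of 24 h (on this read-out lower numbers stand for stronger inhibition and higher numbers for weaker inhibition), compound 2 gives the lowest of the three numbers; compound 1 lies at a 2.0-fold lower number from compound 1 to compound 2 (0.31 log units; beyond the scatter) from it and compound 3 at a 2.1-fold higher number from compound 2 to compound 3 (0.33 log units; beyond the scatter), both steps beyond the scatter. Between compound 1 and compound 3 the step is a 1.0-fold higher number from compound 1 to compound 3 (0.02 log units; within the scatter), within the scatter.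

Compound 4, `COc1cc(OC)c(-c2coc3cc(OCc4cccc(F)c4)ccc3c2=O)cc1OC`, is not yet measured. It differs from compound 2 by 3-fluorophenyl in place of 2-fluorophenyl on a saturated chain carbon bound to an oxygen on an aromatic ring; the two have the same atoms joined differently. Going by the values given here, no measured step moves a fluorine within a phenyl ring, so no step bears on it directly. The steps that touch compound 2 (a 2.0-fold lower number from compound 1 to compound 2 (0.31 log units; beyond the scatter) and a 2.1-fold higher number from compound 2 to compound 3 (0.33 log units; beyond the scatter)) both involve a change of the whole group and were modest. A change of this kind is expected to give a step within the scatter, with no direction favoured, so compound 4 is expected at a 1.2-fold higher number from compound 2 to compound 4 (0.08 log units; within the scatter) from compound 2. The estimate for compound 4 in this assay is 3500 nM, with a range from 1800 nM to 7000 nM.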

Compound 4, half-maximal inhibitory concentration: 3510 nM
Beside the measured number, compound 4's estimate is 1.0-fold (0.00 log units) below it, and the stated range covers the measured number.
By their numbers in this assay, from the lowest: compounds 2, 4, 1 and 3 (each within the scatter of the next, the first and the last beyond it).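

In this assay, going by these compounds alone, the change from 2-fluorophenyl to 3-fluorophenyl on the saturated chain carbon is the first step here that keeps the atoms of the group and alters only how they are joined, and it gives a 1.2-fold higher number from compound 2 to compound 4 (0.08 log units; within the scatter) so these two fluorophenyl isomers are not separated. Compound 4 also stays within the scatter of the two compounds that compound 2 stood apart from, with a 1.7-fold lower number from compound 1 to compound 4 (0.23 log units; within the scatter) and with a 1.8-fold lower number from compound 3 to compound 4 (0.25 log units; within the scatter) so it bridges the modest gaps seen earlier and the four compounds do not fall into two distinct levels. No measurement shown offers a reason for these numbers.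

Still open, as far as these compounds go, is whether 4-fluorophenyl, the remaining fluorophenyl isomer, would also stay within this narrow band. Also open, from the compounds shown here alone, is whether an amine or a carboxylic acid on the phenyl ring, or a longer chain in place of the vinyl group of compound 1, would produce a step clearly larger than the modest ones seen so far in this assay at this position.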